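Series notes: trimming the sulfonamide nitrogen substituent

A few compounds are considered here, and "the series" means these few. Any claim that something is new, unique, unknown or untested is made for them only; others in the source may bear on it.

Measured so far:
- compound 1, `Cc1ccc(S(=O)(=O)N(C)CC(C)C)cc1C#Cc1cc(Cl)ccc1OCC(=O)O`: 4.2 nM
- compound 2, `O=C(O)COc1ccc(Cl)cc1C#Cc1ccccc1`: 108 nM
- compound 3, `CC1(O)c2ccc(C#Cc3cc(Cl)ccc3OCC(=O)O)cc2S(=O)(=O)C1(C)C`: 28 nM

All three numbers come from an assay on CHO cells for displacement of a labelled ligand from prostaglandin D2 receptor 2 (Homo sapiens), read by scintillation counting; a higher number here means a weaker inhibitor, a lower number a stronger inhibitor. Compound 1 holds the lowest number of the three, and both gaps from it are beyond the scatter: compound 3 sits nearer to it, compound 2 furthest away. Compound 2 carries no sulfonyl group at all, while compound 3 carries a cyclic sulfone; compound 1, with its isobutyl(methyl)sulfamoyl group, gives the strongest binding of the set.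

The next compound in line is compound 4, `CNS(=O)(=O)c1ccc(C)c(C#Cc2cc(Cl)ccc2OCC(=O)O)c1`. It differs from compound 1 in one place: hydrogen in place of isobutyl on a sulfonamide nitrogen. The rest of the shared core, including the chlorine, the alkyne and the acid side chain, is untouched.

For the measured compounds named here, no directly comparable pair is available to calibrate this cut. Going by the values given here, the only guidance is that compound 2, lacking the sulfonyl group entirely, gives 108 nM, while compound 1 gives 4.2 nM; compound 4 keeps the sulfonyl and the methyl but loses the isobutyl, so an intermediate outcome seems most plausible. The expected step for compound 4 is a 4.8-fold higher number from compound 1 to compound 4 (0.68 log units; beyond the scatter) in this assay, a loss of potency beyond the scatter. The estimate for compound 4 is 20 nM, with a range of 6 nM to 70 nM.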

Compound 4, inhibition constant: 10 nM
Beside the measured number, compound 4's estimate is 2.0-fold (0.30 log units) above it; the range from low to high includes it.
By their numbers in this assay, from the lowest: compound 1; then compound 4; then compound 3; then compound 2.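

For the compounds shown here, replacing isobutyl with hydrogen on the sulfonamide nitrogen gives a 2.4-fold higher number from compound 1 to compound 4 (0.38 log units; beyond the scatter) in this assay, the first comparison that changes only one place. The step is modest but beyond the scatter, so the isobutyl group adds to binding here, yet it is not needed for a low number: compound 4, with only the methylsulfamoyl group, still gives 10 nM in this series. No measurement at hand accounts for the size of this step.

Still open, going by these compounds, is how the number responds to substituents other than isobutyl on this nitrogen, such as an ethyl group, a longer chain or a cyclopropyl ring. Also open, on these data alone, is what happens when the remaining methyl is replaced by hydrogen, leaving an unsubstituted sulfonamide, or when it is replaced by a larger alkyl group.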